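Carbamoyl to Sulfonyl Exchange on the Shared Core

This account rests on a few compounds, and the source may have more. Where it says the series, first, only, none or still open, it means among the compounds named here.

Measured so far:
- compound 1, `CC(C)[C@H](NC(=O)c1cc(-c2ccc(NC(=O)Nc3ccc(Cl)cc3Oc3ccccc3)cc2)no1)C(=O)O`: 91%
- compound 2, `Cc1ccc(NC(=O)Nc2ccc(-c3cc(C(=O)N[C@H](C(=O)O)C(C)C)on3)cc2)cc1`: 80%

In an assay on isolated protein for inhibition of chondroitin sulfate N-acetylgalactosaminyltransferase 1 (Homo sapiens), read by scintillation counting, with a stated time of 10 min, tested at 1 uM (on this read-out lower numbers stand for less inhibition and higher numbers for more inhibition at the one concentration tested (going by the name of the read-out)), compound 1 gives 91% and compound 2 gives 80%. Compound 2 stands lowest of the two numbers; its nearest neighbour, compound 1, sits higher by a margin beyond the usual scatter. Within the data shown here, no pair of measured compounds differs in a single place, so the series offers no calibrated step to lean on.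

Compound 3, `CC(C)[C@H](NC(=O)c1cc(-c2ccc(NS(=O)(=O)c3c(F)cccc3F)cc2)no1)C(=O)O`, is not yet measured. It differs from compound 2 in one place: (2,6-difluorophenyl)sulfonyl in place of (4-methylphenyl)carbamoyl on a nitrogen on an aromatic ring. Going by these compounds, both measured compounds carry a carbamoyl at that nitrogen, so the sulfonyl is untested. The step of a number 18 percentage points lower from compound 2 to compound 3 (beyond the scatter) is expected to be downward and beyond the scatter, with wide uncertainty. Compound 3 is estimated at 62% in this assay, within a range from 30% to 88%.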

Compound 3, a percentage reported as inhibition, at one concentration (the size of the read-out at that concentration, not a potency): 23%
Estimate against measurement, compound 3: 39 percentage points above, outside the stated range (below it).
By their numbers in this assay, from the lowest: compound 3; then compound 2; then compound 1.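

In this assay, among these compounds, (2,6-difluorophenyl)sulfonyl in place of (4-methylphenyl)carbamoyl on a nitrogen on an aromatic ring gives a number 57 percentage points lower from compound 2 to compound 3 (beyond the scatter) and is the only single-place step so far. The nitrogen on the aromatic ring is therefore a position where the attached group matters a great deal, and the rest of the structure stays the same across this step. No measurement on hand bears on the reason for the step.

Going by these compounds, the exchange alters both the carbamoyl link and the aryl group at once, so the share of each in the step stays open. A (4-methylphenyl)sulfonyl on the same nitrogen would separate the two, while a simple acetyl would show how much of either aryl group this position needs.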